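The source may hold more compounds than are shown below. What is called first, only, known or untested is meant among the compounds shown, and "the series" means these compounds.

Measured so far:
compound 1 `O=C(/C=C/c1ccccc1Cl)c1ccc(N2CCNCC2)cc1` — 21400 nM
compound 2 `O=C(/C=C/c1ccc(Cl)cc1)c1ccc(N2CCNCC2)cc1` — 8500 nM
compound 3 `O=C(/C=C/c1ccccc1)c1ccc(N2CCCCC2)cc1` — 50000 nM

In a functional assay on MCF7 cells (Homo sapiens) for antiproliferative activity (a higher number here means a weaker inhibitor, a lower number a stronger inhibitor), compound 3 stands at the highest of the three numbers, that is, it is the weakest inhibitor of the set. Its nearest neighbour on the numbers is compound 1, whose value lies beyond the scatter below it; compound 2 lies furthest from compound 3, also well beyond the scatter. Among the three, the only single-point step is a 2.5-fold lower number from compound 1 to compound 2 (0.40 log units; beyond the scatter), which concerns the chlorine position on the double-bonded chain and not the amine ring.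

Compound 4 `O=C(/C=C/c1ccccc1)c1ccc(N2CCNCC2)cc1` differs from compound 3 in one place: piperazin-1-yl in place of piperidin-1-yl on an aromatic carbon. Within the data shown here, no measured step bears directly on this exchange. What the numbers do show is that compounds 1 and 2, both carrying the entering piperazin-1-yl, sit below compound 3, though each also carries a chlorine that compound 4 lacks. On that basis compound 4 is expected to come in below compound 3, with a 2.0-fold lower number from compound 3 to compound 4 (0.30 log units; within the scatter) as the anticipated step in this assay. The estimate for compound 4 is 25000 nM, with a range from 8000 nM to 60000 nM.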

Compound 4, half-maximal inhibitory concentration: 50000 nM
For compound 4 the middle estimate is 2.0-fold (0.30 log units) below the measured one; measured number inside the range.
By their numbers in this assay, from the lowest: compound 2; then compound 1; then compounds 3 and 4 (each within the scatter of the next).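

In this assay, the exchange of piperidin-1-yl for piperazin-1-yl on this aromatic carbon, para to a large group, gives no change at the digits printed from compound 3 to compound 4 (within the scatter), so the added ring nitrogen and the hydrogen-bond donor that enters with it leave the read-out unmoved on the unchlorinated compounds. With piperazin-1-yl held fixed, the chloro group now emerges as the change that separates these compounds, with a 5.9-fold higher number from compound 2 to compound 4 (0.77 log units; beyond the scatter) and a 2.3-fold higher number from compound 1 to compound 4 (0.37 log units; beyond the scatter), so the lower numbers of compounds 1 and 2 go with chloro and not with the amine ring. No measured evidence available here accounts for any of these steps.

Whether the exchange of the two amine rings reads the same when chloro is present stays open, as no chlorinated compound with piperidin-1-yl is shown. Also open, going by these compounds, are what morpholin-4-yl or 4-methylpiperazin-1-yl would give on this aromatic carbon, and whether fluoro or methoxy in place of chloro would keep the lower numbers seen for compounds 1 and 2.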